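This account rests on a few compounds, and the source may have more. Where it says the series, first, only, none or still open, it means among the compounds named here.

Measured compounds:
compound 1, `COc1ccc(C2CC2C(=O)NNc2nncc3ccccc23)cc1`: 64000 nM
compound 2, `CC(C)=CCOc1ccc(C2CC2C(=O)NNc2nncc3ccccc23)cc1`: 81000 nM
compound 3, `COc1ccc(C2CC2C(=O)NNC(=O)c2ccncc2)cc1`: > 100000 nM

In a functional assay on PC-3 cells (Homo sapiens) for inhibition, read by MTT assay, with a stated time of 72 h (a higher number here means a weaker inhibitor, a lower number a stronger inhibitor), compound 1 gives 64000 nM. Compound 2 carries the change 2-methylprop-1-en-1-yl in place of hydrogen on a saturated chain carbon bound to an oxygen on an aromatic ring and gives 81000 nM. The step of a 1.3-fold higher number from compound 1 to compound 2 (0.10 log units; within the scatter) is small. Compound 3 has a different core from compound 1, and the difference between the two cores is not broken down here. In this assay compound 3 reaches only a limit of the assay, > 100000 nM, which is the limit (the limit of > 100000 nM in this assay, at which 1 of the 3 values shown sits). Compound 4, `CC(C)=CCOc1ccc(C2CC2C(=O)NNC(=O)c2ccncc2)cc1`, has not yet been measured; it differs from compound 3 by 2-methylprop-1-en-1-yl in place of hydrogen on a saturated chain carbon bound to an oxygen on an aromatic ring, the same change that separates compound 1 from compound 2. Because a 1.3-fold higher number from compound 1 to compound 2 (0.10 log units; within the scatter) lies within the scatter, the step that the limit leaves unreadable from compound 3 to compound 4 is expected to be small too. Compound 4 is therefore estimated at 150000 nM, most likely again only a limit.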

Compound 4, half-maximal inhibitory concentration: > 100000 nM
Compound 4 was reported as a limit; the forecaster's own chance of this, stated with the estimate: 75%; the middle value is on the limit's open side.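

Among the compounds shown here, compound 3 and compound 4 both give only a limit in this assay and no step between them can be read, because both sit at that limit: the limit of > 100000 nM in this assay, at which 2 of the 4 values shown sit.

The compounds shown leave open whether changing methoxy to (3-methylbut-2-en-1-yl)oxy alters inhibition on the core of compound 3.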